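Thiocyanate and Selenocyanate Benzyl Analogues in Prostate Cell Growth

The source may report more compounds than this note shows. Statements on the series, on what has been measured and on what is new or still open speak of the compounds shown alone.

Measured compounds:
- compound 1, `Cc1noc(C)c1CSC#N`: 13800 nM
- compound 2, `N#CSCc1ccc(-n2cccc2)cc1`: 60300 nM

Two compounds carry a cyanosulfanyl group on a saturated chain carbon bound to an aromatic carbon. In a functional assay on PC-3 cells (Homo sapiens) for cytotoxicity, read by MTT assay, with a stated time of 72 h (a higher number here means a weaker inhibitor of growth, a lower number a stronger inhibitor of growth), compound 1 gives 13800 nM. In this assay compound 2 gives 60300 nM, the highest of the two numbers; its nearest neighbour is compound 1, whose number is lower by a gap that lies beyond the scatter of the method. For the measured compounds named here, the two compounds share no core and differ in more than one place, so their two values show only that the pair spans a clear gap, with compound 2 the weaker of the two.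

Compound 3, `N#C[Se]Cc1ccc(-n2cccc2)cc1`, keeps the core of compound 2 and changes one thing: a group of 3 heavy atoms (1 carbon, 1 nitrogen, 1 selenium; no ring) in place of a group of 3 heavy atoms (1 carbon, 1 nitrogen, 1 sulfur; no ring), on a saturated chain carbon bound to an aromatic carbon. No comparison of this kind exists among the measured compounds, so the size of the step from compound 2 to compound 3 is not known from the data. The account expects a step in this assay toward a lower number, of a size that might reach beyond the scatter, estimated as a 4.0-fold lower number from compound 2 to compound 3 (0.60 log units; beyond the scatter). For compound 3 the estimated value in this assay is 15000 nM, with an expected range from 3000 nM to 60000 nM.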

Compound 3, concentration for total growth inhibition: > 100000 nM
Compound 3: no number, only a limit (the forecaster's own chance of this, stated with the estimate: 5%); middle value at least 6.6-fold (0.82 log units) from the limit.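

For the compounds shown here, compound 3 gives the first comparison in this set in which only one place changes, on a saturated chain carbon bound to an aromatic carbon. In this assay, putting the selenium group in place of cyanosulfanyl on the shared core gives an at least 1.6-fold higher number from compound 2 to compound 3 (0.21 log units; that floor lies within the scatter), and the exchange of this single atom therefore brings no lower number on this core. The reading for compound 3 is a limit of the assay and not a number, and the step is only a floor, with its full size unknown: the limit of > 100000 nM in this assay, at which 1 of the 3 values shown sits.

The compounds shown leave open what number lies behind that limit, and whether the same exchange on the core of compound 1 would move the reading in the same direction. Also open, going by these compounds, is how this place responds to a group of another kind on the saturated chain carbon, such as an amine or a carboxylic acid, or to a longer chain carrying the cyanosulfanyl group.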